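The compounds below may be only part of what the source reports. "The series", "measured", "known", "first", "only" and "open" are said of these compounds alone.

Compound 3 `C[C@@H](NC(=O)c1ccccc1Cl)[C@H]1CC[C@@H](c2ccnc3ccc(F)cc32)CC1` is the amide that stands at the low end of the numbers seen so far. In an assay on blood for inhibition of Indoleamine 2,3-dioxygenase 1 (Homo sapiens), read by mass spectrometry, with stated times of 4 h and 18 h (on this read-out higher numbers stand for weaker inhibition and lower numbers for stronger inhibition), compound 3 gives 135 nM. Compound 1 `C[C@@H](C(=O)NC1CCCCC1)[C@H]1CC[C@@H](c2ccnc3ccc(F)cc32)CC1`, which carries its amide the other way round with the cyclohexyl on the nitrogen, gives 470 nM in this assay, and compound 2 `C[C@@H](NS(=O)(=O)c1ccc(Cl)cc1)[C@H]1CC[C@@H](c2ccnc3ccc(F)cc32)CC1`, the sulfonamide, gives 484 nM in this assay. For the measured compounds named here, the only single-point step among the three is the exchange of the sulfonyl for the carbonyl, which brought a 3.6-fold lower number from compound 2 to compound 3 (0.55 log units; beyond the scatter).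

Compound 4 `C[C@@H](NC(=O)C1CCCCC1)[C@H]1CC[C@@H](c2ccnc3ccc(F)cc32)CC1` differs from compound 3 by cyclohexyl in place of 2-chlorophenyl on a carbonyl carbon. Going by the values given here, no measured step isolates this exchange: compound 1 and compound 3 differ in more than one place, so their two values can only be set side by side, and the step between compound 2 and compound 3 concerns the linking group rather than the ring. What the side-by-side values of compound 1 and compound 3 show is that the cyclohexyl amide stood higher than the aryl amide, and on that slender basis a higher number is expected for compound 4, with a 2.6-fold higher number from compound 3 to compound 4 (0.41 log units; beyond the scatter) as the estimated step. Compound 4 is therefore expected to give about 350 nM in this assay, within a range from 120 nM to 1000 nM.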

Compound 4, half-maximal inhibitory concentration: 294 nM
Estimate against measurement, compound 4: 1.2-fold (0.08 log units) above, within the range that was stated.
By their numbers in this assay, from the lowest: compound 3; then compounds 4, 1 and 2 (each within the scatter of the next).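

In this assay, for the compounds shown here, the ring on the carbonyl carbon of the amide matters: the exchange of 2-chlorophenyl for cyclohexyl gives a 2.2-fold higher number from compound 3 to compound 4 (0.34 log units; beyond the scatter) and is the first direct test of this ring in an amide of this kind. The cyclohexyl amide does not stand apart from the sulfonamide, with a 1.6-fold lower number from compound 2 to compound 4 (0.22 log units; within the scatter) as the step, so a carbonyl on the amine nitrogen does not by itself separate an amide from the sulfonamide, and the low number of the 2-chlorophenyl amide depends on the ring that the carbonyl carries. Turning the amide round also leaves the two cyclohexyl amides unseparated, with a 1.6-fold lower number from compound 1 to compound 4 (0.20 log units; within the scatter) as the step.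

The compounds shown leave open whether the chlorine or the aromatic ring of the 2-chlorophenyl group accounts for the step, and how an amine, a carboxylic acid or a longer chain on the carbonyl carbon would read. No measurement at hand gives a reason for the step.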